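Swapping Bromo for Fluoro on the Sulfanyl Phenyl Ring

The source may hold more compounds than are shown below. What is called first, only, known or untested is meant among the compounds shown, and "the series" means these compounds.

The measured compounds and their numbers:
compound 1 `CC(O)(CSc1ccc(F)cc1)c1nc(-c2ccc(Cl)cc2)no1`: 36300 nM
compound 2 `CC(O)(CSc1ccccc1)c1nc(-c2ccc(F)c(Cl)c2)no1`: 5500 nM
compound 3 `CC(O)(CSc1ccc(Br)cc1)c1nc(-c2ccc(F)c(Cl)c2)no1`: 8800 nM

In a functional assay on DU-145 cells (Homo sapiens) for cytotoxicity, read by MTT assay (on this read-out lower numbers stand for stronger inhibition and higher numbers for weaker inhibition), compound 3 gives 8800 nM, the second highest of the three numbers. Its nearest neighbour is compound 2, which in this assay gives 5500 nM; the two lie within the scatter of each other. Compound 1, which in this assay gives 36300 nM, stands furthest away, beyond the scatter.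

Compound 4 `CC(O)(CSc1ccc(F)cc1)c1nc(-c2ccc(F)c(Cl)c2)no1` has not yet been measured. It differs from compound 3 in one place: fluoro in place of bromo on an aromatic carbon.

Among the compounds with values here, only one measured step touches this position: a 1.6-fold higher number from compound 2 to compound 3 (0.20 log units; within the scatter). Adding a bromo there left the number essentially where it was. Compound 1 carries the same (4-fluorophenyl)sulfanyl group as compound 4, but it also differs from compound 4 on the other ring, so its value cannot be read as a step to compound 4.

On that basis compound 4 is expected to change little: a 1.1-fold lower number from compound 3 to compound 4 (0.04 log units; within the scatter) is the estimated step, with the number staying within the scatter of compound 3. The estimate for compound 4 in this assay is 8000 nM, with a range from 3500 nM to 18000 nM.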

Compound 4, half-maximal inhibitory concentration: 2900 nM
Compound 4: middle estimate off by 2.8-fold (0.44 log units), on the high side, and the stated range ends above it.
By their numbers in this assay, from the lowest: compounds 4, 2 and 3 (each within the scatter of the next, the first and the last beyond it); then compound 1.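

In this assay, the change from bromo to fluoro on the aromatic carbon para to a large group has a measurable size, with a 3.0-fold lower number from compound 3 to compound 4 (0.48 log units; beyond the scatter), which lies beyond the scatter. Neither halogen separates clearly from hydrogen at this position, since a 1.6-fold higher number from compound 2 to compound 3 (0.20 log units; within the scatter) and a 1.9-fold lower number from compound 2 to compound 4 (0.28 log units; within the scatter) both lie within the scatter, so the two halogen compounds differ from each other while each stays close to the compound carrying hydrogen. With the (4-fluorophenyl)sulfanyl group held constant, the other ring gives a much larger step, a 13-fold lower number from compound 1 to compound 4 (1.10 log units; beyond the scatter), for 3-chloro-4-fluorophenyl in place of 4-chlorophenyl, and nothing shown here accounts for either difference.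

Within the data shown here, whether the step on the other ring keeps its size with bromo or hydrogen on the sulfanyl phenyl ring remains open, since that replacement is seen only with fluoro. Going by these compounds, it is also open where groups such as a methoxy, an amine or a carboxylic acid would fall at this position, and whether the gap between fluoro and bromo extends to them.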